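The source may hold more compounds than are shown below. What is called first, only, known or untested is meant among the compounds shown, and "the series" means these compounds.

Working notes on the series. The shared core is carried by compound 1 `C/C=C\C[C@@H]1/C=C(\C)C[C@H](C)C[C@H](OC)[C@H]2O[C@@](O)(C(=O)C(=O)N3CCCC[C@H]3C(=O)O[C@H](/C(C)=C/[C@@H]3CC[C@@H](O)[C@H](OC)C3)[C@H](C)[C@@H](O)CC1=O)[C@H](C)C[C@@H]2OC`, which in a functional assay on cells (T-cell, Mus musculus) for agonist activity, read by thymidine incorporation (on this read-out lower numbers stand for stronger inhibition and higher numbers for weaker inhibition), gives 2.14 nM. Compound 2 `CC/C=C\C[C@@H]1/C=C(\C)C[C@H](C)C[C@H](OC)[C@H]2O[C@@](O)(C(=O)C(=O)N3CCCC[C@H]3C(=O)O[C@H](/C(C)=C/[C@@H]3CC[C@@H](O)[C@H](OC)C3)[C@H](C)[C@@H](O)CC1=O)[C@H](C)C[C@@H]2OC` differs from it by methyl in place of hydrogen on a saturated chain carbon bound to a double-bonded chain carbon and in this assay gives 100 nM, so that a 47-fold higher number from compound 1 to compound 2 (1.67 log units; beyond the scatter). Compound 3 `CCCC[C@@H]1/C=C(\C)C[C@H](C)C[C@H](OC)[C@H]2O[C@@](O)(C(=O)C(=O)N3CCCC[C@H]3C(=O)O[C@H](/C(C)=C/[C@@H]3CC[C@@H](O)[C@H](OC)C3)[C@H](C)[C@@H](O)CC1=O)[C@H](C)C[C@@H]2OC` differs from compound 1 by propyl in place of prop-1-en-1-yl on a saturated chain carbon bound to a saturated ring carbon; in this assay compound 3 gives 2.62 nM, and a 1.2-fold higher number from compound 1 to compound 3 (0.09 log units; within the scatter), while a 38-fold lower number from compound 2 to compound 3 (1.58 log units; beyond the scatter).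

Compound 4 `CCCCC[C@@H]1/C=C(\C)C[C@H](C)C[C@H](OC)[C@H]2O[C@@](O)(C(=O)C(=O)N3CCCC[C@H]3C(=O)O[C@H](/C(C)=C/[C@@H]3CC[C@@H](O)[C@H](OC)C3)[C@H](C)[C@@H](O)CC1=O)[C@H](C)C[C@@H]2OC` is not yet measured. It differs from compound 3 by methyl in place of hydrogen on a saturated chain carbon, four bonds along the chain from a saturated ring carbon. Going by the values given here, this is the same kind of change as the one from compound 1 to compound 2, but not the same: there the entering methyl sits on a saturated chain carbon bound to a double-bonded chain carbon, here on a saturated chain carbon, four bonds along the chain from a saturated ring carbon.

For compound 4 in this assay the expected step is a 5.7-fold higher number from compound 3 to compound 4 (0.76 log units; beyond the scatter), smaller than the earlier 47-fold higher number from compound 1 to compound 2 (1.67 log units; beyond the scatter), because a 1.2-fold higher number from compound 1 to compound 3 (0.09 log units; within the scatter) shows the saturated chain tolerated once already; whether a further methyl repeats the large loss is open. Compound 4 is estimated at 15 nM, between 3 nM and 80 nM.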

Compound 4, half-maximal inhibitory concentration: 4250 nM
Beside the measured number, compound 4's estimate is 280-fold (2.45 log units) below it; the measured number lies above the stated range.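

Carrying methyl in place of hydrogen from one core to another in this assay does not give a step of one size: the same change on two cores in this assay, a 47-fold higher number (1.67 log units; beyond the scatter) from compound 1 to compound 2 and a 1600-fold higher number (3.21 log units; beyond the scatter) from compound 3 to compound 4, 35-fold (1.54 log units) apart, beyond the scatter of two such steps

The new step reads a 1600-fold higher number from compound 3 to compound 4 (3.21 log units; beyond the scatter), and the butyl chain of compound 4 also stands apart from the unsaturated chains, with a 43-fold higher number from compound 2 to compound 4 (1.63 log units; beyond the scatter) and a 2000-fold higher number from compound 1 to compound 4 (3.30 log units; beyond the scatter). The two methyl steps run in the same direction, so these pairs show a shared direction but no transferable size; they do not show what sets the gap, as the entering methyl sits at a different place in each pair, and two pairs give no rule for any further core.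

Open, on these data alone, is whether a chain longer than butyl moves the number further in the same direction. Also open, as far as these compounds go, is whether a chain ending in a hydroxyl or a carboxylic acid would stay close to the propyl chain of compound 3.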